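The compounds below may be only part of what the source reports. "The series", "measured", "known", "first", "only" and "open" are said of these compounds alone.

Measured compounds in a functional assay on MDA-MB-231 cells (Homo sapiens) for inhibition, read by sulforhodamine B assay, with a stated time of 72 h; on this read-out higher numbers stand for weaker inhibition of growth and lower numbers for stronger inhibition of growth:
- compound 1 `NC(=O)/C=C/c1ccncc1-c1ccc2ccccc2c1`: > 10000 nM, a limit of the assay rather than a number
- compound 2 `CNC(=O)/C=C/c1ccncc1-c1ccc2c(cnn2C)c1`: > 10000 nM, likewise a limit of the assay
- compound 3 `CNC(=O)/C=C/c1ccncc1-c1ccc2c(ccn2C)c1`: 8550 nM

Compound 1 stands only at a limit in this assay; no number is known for it. This is the common situation in the set, since (the limit of > 10000 nM in this assay, at which 2 of the 3 values shown sit). Within the data shown here, compound 3 is the only compound with a numbered value, and it is weak. Among the measured compounds shown here, no step between two measured compounds is defined here, so no measured change in this assay can be drawn on for the next compound.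

Compound 4 `CCOC(=O)/C=C/c1ccncc1-c1ccc2ccccc2c1` differs from compound 1 in one place: ethoxy in place of amino on a carbonyl carbon. The difference is a change at the carbamoyl carbon with the rest of the structure untouched. Given that compound 1 sits at > 10000 nM, no step beyond the scatter is expected in this assay, and the most likely outcome is again a limit. Compound 4 is expected at about 12000 nM, within 5000 nM to 30000 nM. The step this implies, a step that the limit leaves unreadable from compound 1 to compound 4, is expected to be within the scatter.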

Compound 4, concentration for 50% growth inhibition: 8090 nM
Compound 4: the middle estimate sits 1.5-fold (0.17 log units) above what was measured; the range from low to high includes it.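

In this assay, ethoxy in place of amino on a carbonyl carbon gives an at least 1.2-fold lower number from compound 1 to compound 4 (0.09 log units; that floor lies within the scatter), so this position now has a step that can be read, though only as a floor. Compound 4 gives the core of compound 1 a numbered value rather than a limit, and it does so with the ethoxycarbonyl group, which has no hydrogen-bond donor at this place. Compound 1 reads > 10000 nM, which is a limit of the assay, and such limits remain common in the set: the limit of > 10000 nM in this assay, at which 2 of the 4 values shown sit.

From the compounds shown here alone, the true size of the step cannot be read, so whether ethoxy differs from amino beyond the scatter stays open. Also open, going by these compounds, is how a carboxylic acid, a methyl ester or a longer alkoxy chain on the same carbonyl carbon would read against compound 4.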